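Trading the Pyridinyl Arm for an Ethenyl Amide

The source may hold more compounds than are shown below. What is called first, only, known or untested is meant among the compounds shown, and "the series" means these compounds.

Three compounds sharing the core of compound 3 `COc1ccc(-c2cccc(C(=O)N(C)C)n2)cc1S(=O)(=O)Nc1cccc(NCCNC(=O)c2cccc(C)c2)c1` have been tested in a functional assay on CHO-RD-HGA16 cells for agonist activity at Orexin/Hypocretin receptor type 1 (Homo sapiens), read by fluorescence and calcium flux, with a stated time of 30 min; a lower number here means that less compound is needed, a higher number that more compound is needed for the effect. Compound 3 gives 226 nM, the lowest of the three numbers; compound 1 `COc1ccc(-c2cccc(C(=O)N(C)C)c2)cc1S(=O)(=O)Nc1cccc(NCCCNC(=O)c2cccc(C)c2)c1` gives 400 nM, within the scatter of it, while compound 2 `COc1ccc(-c2cccc(C(=O)N(C)C)c2)cc1S(=O)(=O)Nc1cccc(NCC(C)NC(=O)c2cccc(C)c2)c1` gives 666 nM, beyond the scatter. Among the compounds with values here, the only measured step, a 1.7-fold higher number from compound 1 to compound 2 (0.22 log units; within the scatter), concerns the saturated chain and a different part of the molecule. Compound 4 `COc1ccc(/C=C/C(=O)N(C)C)cc1S(=O)(=O)Nc1cccc(NCCNC(=O)c2cccc(C)c2)c1` differs from compound 3 by 2-(dimethylcarbamoyl)ethenyl in place of 6-(dimethylcarbamoyl)pyridin-2-yl on an aromatic carbon. Within the data shown here, no measured step bears on this exchange, so the expectation rests on the values alone and is uncertain; a weakening, possibly beyond the scatter, is expected. The estimate for compound 4 in this assay is 600 nM, with a range from 150 nM to 2500 nM, which is expected to mean a step of a 2.7-fold higher number from compound 3 to compound 4 (0.42 log units; beyond the scatter).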

Compound 4, half-maximal effective concentration: > 10000 nM
Compound 4: a limit, no number (the forecaster's own chance of this, stated with the estimate: 10%); middle value at least 16-fold (1.22 log units) away from the limit.
By their numbers in this assay, from the lowest: compounds 3, 1 and 2 (each within the scatter of the next, the first and the last beyond it). At a limit, above all of these: compound 4.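

Within the data shown here, replacing 6-(dimethylcarbamoyl)pyridin-2-yl with 2-(dimethylcarbamoyl)ethenyl on this aromatic carbon, para to a methoxy group, gives an at least 44-fold higher number from compound 3 to compound 4 (1.64 log units; beyond the scatter), a large step, whereas the only earlier step, on the saturated chain, stayed within the scatter. Among these compounds, all three earlier compounds carry a six-membered aromatic ring at this position, so this is the first sign of how much the position tolerates. The reading for compound 4 is a limit, not a number: the limit of > 10000 nM in this assay, at which 1 of the 4 values shown sits.

From the compounds shown here alone, it remains open whether the ring's absence or the ethenyl link accounts for this step. A saturated ethyl chain bearing the same dimethylcarbamoyl group, or a simple amine at this position, would bear on that question.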